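Extending the hydroxycarbamoyl chain beyond compound 3

The source may report more compounds than this note shows. Statements on the series, on what has been measured and on what is new or still open speak of the compounds shown alone.

Among the measured compounds shown here, in a functional assay on MCF7 cells (Homo sapiens) for antiproliferative activity, read by MTT assay, with a stated time of 48 h (on this read-out higher numbers stand for weaker inhibition and lower numbers for stronger inhibition), compound 3 `COc1cc2ncnc(Nc3cc(Cl)ccc3Cl)c2cc1OCCCCC(=O)NO` gives 13700 nM, the second highest of the three numbers so far. Compound 2 `COc1cc2ncnc(Nc3cc(Cl)ccc3Cl)c2cc1OCCCC(=O)NO` stands higher at 44500 nM, and compound 1 `COc1cc2ncnc(Nc3cccc(Br)c3)c2cc1OCCCCCC(=O)NO` stands lower at 2800 nM. Compound 4 `COc1cc2ncnc(Nc3cc(Cl)ccc3Cl)c2cc1OCCCCCC(=O)NO` has not yet been measured. Relative to compound 3 it shows this difference: (hydroxycarbamoyl)methyl in place of hydroxycarbamoyl on a saturated chain carbon, four bonds along the chain from an oxygen on an aromatic ring. The same kind of change, made three bonds along the chain from an oxygen on an aromatic ring, gave a 3.2-fold lower number from compound 2 to compound 3 (0.51 log units; beyond the scatter). For the measured compounds named here, that modest step is the only direct precedent, and one step does not establish a trend. Compound 4 has the same chain as compound 1 but differs elsewhere in the structure, so the value of compound 1 at 2800 nM is only loose support. A second modest step towards a lower number is therefore expected in this assay. The expected step is a 2.5-fold lower number from compound 3 to compound 4 (0.40 log units; beyond the scatter). For compound 4 the estimated value is 5500 nM, with an expected range of 2200 nM to 13000 nM.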

Compound 4, half-maximal inhibitory concentration: 4000 nM
The estimate for compound 4 lay 1.4-fold (0.14 log units) above the measured number; the range from low to high includes it.
By their numbers in this assay, from the lowest: compounds 1 and 4 (each within the scatter of the next); then compound 3; then compound 2.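

In this assay, the added chain length again gives a modest change one bond further out, a 3.4-fold lower number from compound 3 to compound 4 (0.53 log units; beyond the scatter), in the same direction as a 3.2-fold lower number from compound 2 to compound 3 (0.51 log units; beyond the scatter). Two successive steps now run the same way across the 2,5-dichlorophenyl compounds, and together they amount to a large change, an 11-fold lower number from compound 2 to compound 4 (1.05 log units; beyond the scatter). With the chain held constant, 2,5-dichlorophenyl in place of 3-bromophenyl on a nitrogen on an aromatic ring gives a 1.4-fold higher number from compound 1 to compound 4 (0.15 log units; within the scatter), so this change does not separate the two compounds.

On these data alone, it remains open whether a longer chain would continue this direction or reverse it, and whether a carboxylic acid could take the place of the hydroxycarbamoyl end. No evidence is available to explain the effect of chain length on these numbers.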